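The compounds below may be only part of what the source reports. "The series", "measured", "known", "first", "only" and "open" are said of these compounds alone.

Measured in a functional assay (muscle tissue) with Cavia porcellus as the target; on this read-out lower numbers stand for an effect already at smaller amounts and higher numbers for an effect only at larger amounts of compound:

- compound 1 `COC(=O)C1=C(C)N=C(C)/C(=C(\O)OC)C1c1ccccc1Cl`: 2.19 nM
- compound 2 `COC(=O)C1=C(C)N=C(C)/C(=C(\O)OC)C1c1cccc(O)c1`: 1000 nM
- compound 3 `COC(=O)C1=C(C)N=C(C)/C(=C(\O)OC)C1c1cccc(C)c1`: 110 nM

Of these three, compound 3 holds the middle value. Compound 4 `COC(=O)C1=C(C)N=C(C)/C(=C(\O)OC)C1c1c(Cl)cccc1Cl` has not yet been measured. It carries 2,6-dichlorophenyl in place of 3-methylphenyl on a saturated ring carbon.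

The closest guide is the large step of a 50-fold higher number from compound 1 to compound 3 (1.70 log units; beyond the scatter), where 3-methylphenyl replaced 2-chlorophenyl. The 2,6-dichlorophenyl group of compound 4 also has the chlorine-bearing pattern of the 2-chlorophenyl group, so much of that step may be reversed. The large step of a 460-fold higher number from compound 1 to compound 2 (2.66 log units; beyond the scatter) and the modest step of a 9.1-fold lower number from compound 2 to compound 3 (0.96 log units; beyond the scatter) show that the number in this assay responds strongly to changes in this phenyl group. Among the measured compounds shown here, no measured compound carries the 2,6-dichlorophenyl group, so the effect of its second chlorine is unknown.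

A large move towards a lower number is expected, with an estimated step of a 9.2-fold lower number from compound 3 to compound 4 (0.96 log units; beyond the scatter). The estimate for compound 4 is 12 nM, with an expected range from 3 nM to 60 nM.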

Compound 4, half-maximal effective concentration: 1.91 nM
Compound 4: middle estimate off by 6.3-fold (0.80 log units), on the high side; the measured number lies below the stated range.
By their numbers in this assay, from the lowest: compounds 4 and 1 (each within the scatter of the next); then compound 3; then compound 2.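

Adding a second chlorine to the phenyl group of compound 1 makes no readable difference in this assay (a 1.1-fold lower number from compound 1 to compound 4 (0.06 log units; within the scatter)). Set against the groups without chlorine, 2,6-dichlorophenyl stands far apart (a 58-fold lower number from compound 3 to compound 4 (1.76 log units; beyond the scatter)) and further still from the hydroxy-bearing group (a 520-fold lower number from compound 2 to compound 4 (2.72 log units; beyond the scatter)). Among these four compounds, the two with a chlorine-bearing phenyl group therefore share the low end of the scale, with no exception, which the single 2-chlorophenyl example could not show.

Still open, from the compounds shown here alone, is where a 3-chlorophenyl group, a 2-methylphenyl group or a phenyl group carrying an amine would fall, and so whether chlorine itself or simply the place it occupies on the phenyl group goes with the low numbers. Nothing available explains why these phenyl groups differ so widely.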